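The source may report more compounds than this note shows. Statements on the series, on what has been measured and on what is new or still open speak of the compounds shown alone.

In a functional assay on the whole organism with Mus musculus as the target (a higher number here means that more compound is needed for the effect, a lower number that less compound is needed), three related compounds have been measured so far. Compound 1 `NC(=O)CNCc1ccccc1` gives 490 mg/kg, compound 2 `C[C@@H](NCc1ccc(Oc2ccccc2)cc1)C(N)=O` gives 64 mg/kg, and compound 3 `CNC(=O)[C@@H](CO)NCc1ccc(OCc2ccccc2C(F)(F)F)cc1` gives 85.6 mg/kg. Compound 2 therefore sits at the low end of this small set, where less compound is needed, and it shares that place with compound 3. The two numbers lie within the usual scatter of each other. The gap from compound 2 up to compound 1 is beyond that scatter.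

The next compound is compound 4 `C[C@@H](NCc1ccc(OCc2cccs2)cc1)C(N)=O`, which keeps the shared core of compound 2 and changes one group: (thiophen-2-yl)methyl in place of phenyl on an oxygen on an aromatic ring. Going by the values given here, no two measured compounds differ in one place only, so the data offer no direct guide to a change of this kind. The closest hint is compound 3, which also has a ring attached through a carbon on that oxygen and gives 85.6 mg/kg, although it differs from compound 2 elsewhere too. The expected step of a 1.1-fold lower number from compound 2 to compound 4 (0.03 log units; within the scatter) is therefore none beyond the scatter, with neither direction favoured. For compound 4, the estimated value is 60 mg/kg, with an expected range of 20 mg/kg to 160 mg/kg.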

Compound 4, dose for half-maximal effect: 61.6 mg/kg
Estimate against measurement, compound 4: 1.0-fold (0.01 log units) below; measured number inside the range.
By their numbers in this assay, from the lowest: compounds 4, 2 and 3 (each within the scatter of the next); then compound 1.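

In this assay, going by these compounds alone, replacing phenyl with (thiophen-2-yl)methyl on an oxygen on an aromatic ring gives a 1.0-fold lower number from compound 2 to compound 4 (0.02 log units; within the scatter), the first step in this set in which the two compounds differ in one place only. At this position, then, the two compounds read alike within the scatter, even though a six-membered aromatic ring of carbon only leaves and a five-membered aromatic ring with a sulfur atom enters, and the count of hydrogen-bond acceptors in the group rises. No measured property of these groups is available to account for this result.

The ring and the carbon link between it and the oxygen changed together in this one step, so the compounds shown cannot tell whether each alone would leave the number in place or whether two separate effects happen to cancel. They also leave open how much this position accepts beyond these two groups, for example an amine or a carboxylic acid on the ring, or a longer chain between the oxygen and the ring.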